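The source may hold more compounds than are shown below. What is called first, only, known or untested is meant among the compounds shown, and "the series" means these compounds.

In a functional assay on HeLa cells (Homo sapiens) for cytotoxicity, read by resazurin assay, with a stated time of 72 h (a lower number here means a stronger inhibitor, a higher number a weaker inhibitor), compound 3 `COc1cc(/C=C/C(=O)OCCCCCO[N+](=O)[O-])ccc1O` gives 13400 nM. For compound 1 `COc1cc(/C=C/C(=O)OCCCCCO[N+](=O)[O-])ccc1OCCCCCO[N+](=O)[O-]` this assay reports a limit, > 50000 nM. Compound 2 `COc1cc(/C=C/C(=O)OC/C=C/CO[N+](=O)[O-])ccc1O` gives 1000 nM, a lower number than compound 3 and beyond the scatter, so compound 3 stands with the higher of the two numbers shown. Among the compounds with values here, the one measured step, an at least 3.7-fold lower number from compound 1 to compound 3 (0.57 log units; beyond the scatter), alters a different part of the molecule and says nothing about the chain that carries the ester. Compound 4 `COc1cc(/C=C/C(=O)OCCCO[N+](=O)[O-])ccc1O` differs from compound 3 by nitrooxy in place of 2-(nitrooxy)ethyl on a saturated chain carbon, three bonds along the chain from an oxygen next to a carbonyl group. Within the data shown here, compound 2 gives the lower number with a different linker, but no measured step isolates chain length, so only a modest step toward a lower number, a 1.7-fold lower number from compound 3 to compound 4 (0.22 log units; within the scatter), is expected. Compound 4 is estimated at 8000 nM, between 2500 nM and 25000 nM.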

Compound 4, half-maximal inhibitory concentration: 6700 nM
Compound 4: the middle estimate sits 1.2-fold (0.08 log units) above what was measured; low and high end bracket the measured number.
By their numbers in this assay, from the lowest: compound 2; then compounds 4 and 3 (each within the scatter of the next). At a limit, above all of these: compound 1.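

Nitrooxy in place of 2-(nitrooxy)ethyl gives a 2.0-fold lower number from compound 3 to compound 4 (0.30 log units; within the scatter) and so leaves this shorter chain not told apart from the longer one. A real gap appears only with the other linker, with a 6.7-fold higher number from compound 2 to compound 4 (0.83 log units; beyond the scatter) as the step, so at this position the kind of chain can count for more than trimming it. Nothing shown gives a cause for either step. Going by these compounds, whether 4-(nitrooxy)butyl would sit with the saturated chains or with the other linker stays open, as does the effect of an amine in place of nitrooxy.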